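This account rests on a few compounds, and the source may have more. Where it says the series, first, only, none or still open, it means among the compounds named here.

Three compounds have been measured in a functional assay on KB cells (Homo sapiens) for antiproliferative activity, read by MTT assay, with a stated time of 72 h; a lower number here means a stronger inhibitor, a higher number a weaker inhibitor:

compound 1 `CN(C(=O)c1ccc(Br)cc1)c1ccc2[nH]c(-c3n[nH]c4ccccc34)cc2n1`, 1780 nM
compound 2 `COc1ccc(C(=O)N(C)c2ccc3[nH]c(-c4n[nH]c5ccccc45)cc3n2)cc1`, 12900 nM
compound 3 `CN(c1ccc2[nH]c(-c3n[nH]c4ccccc34)cc2n1)S(=O)(=O)c1ccc(Br)cc1`, 7150 nM

Compound 1 and compound 2 differ in one place only, (methoxy in place of bromo on an aromatic carbon), and that change gave a 7.2-fold higher number from compound 1 to compound 2 (0.86 log units; beyond the scatter). Compound 3 differs from compound 1 in (4-bromophenyl)sulfonyl in place of (4-bromophenyl)carbonyl on a nitrogen on an aromatic ring, which gave a 4.0-fold higher number from compound 1 to compound 3 (0.60 log units; beyond the scatter). Between compound 2 and compound 3 there is a 1.8-fold lower number from compound 2 to compound 3 (0.26 log units; within the scatter), so these two cannot be told apart.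

Compound 4 `COc1ccc(S(=O)(=O)N(C)c2ccc3[nH]c(-c4n[nH]c5ccccc45)cc3n2)cc1` has not yet been measured in this assay. It differs from compound 3 in methoxy in place of bromo on an aromatic carbon. Going by the values given here, this is the same change as the one between compound 1 and compound 2, and the place of the change reads the same in both cases; what separates the two cores is (4-bromophenyl)sulfonyl in place of (4-bromophenyl)carbonyl on a nitrogen on an aromatic ring. Because the earlier example of this change gave a 7.2-fold higher number from compound 1 to compound 2 (0.86 log units; beyond the scatter), a step in the same direction is expected here, though with a single precedent on a different core its size is uncertain. The step from compound 3 to compound 4 is expected to be a 4.2-fold higher number from compound 3 to compound 4 (0.62 log units; beyond the scatter). Compound 4 is therefore estimated at 30000 nM, most likely between 10000 nM and 100000 nM.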

Compound 4, half-maximal inhibitory concentration: 22100 nM
The estimate for compound 4 lay 1.4-fold (0.13 log units) above the measured number; the measured number falls inside the stated range.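

In this assay, replacing bromo with methoxy on the core of compound 3 gave a 3.1-fold higher number from compound 3 to compound 4 (0.49 log units; beyond the scatter) and so made the compound a weaker inhibitor, the same direction as on the core of compound 1. The change therefore carried over between the carbonyl and sulfonyl cores in direction, and the two step sizes cannot be told apart: the same change on two cores in this assay, a 7.2-fold higher number (0.86 log units; beyond the scatter) from compound 1 to compound 2 and a 3.1-fold higher number (0.49 log units; beyond the scatter) from compound 3 to compound 4, 2.3-fold (0.37 log units) apart, within the scatter of two such steps

Going by these compounds alone, this is still only two examples of one change, so it does not show that the step would keep its direction or size on any other core, and it does not explain why methoxy gives the higher number.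

The compounds shown carry only bromo or methoxy at this place on the ring, which leaves open how a fluoro group, an amine or a carboxylic acid would read there. On these data alone, all four also keep the same methyl group on the nitrogen bearing the carbonyl or sulfonyl, so the effect of a longer chain at that nitrogen remains unknown.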